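A few compounds are considered here, and "the series" means these few. Any claim that something is new, unique, unknown or untested is made for them only; others in the source may bear on it.

Three compounds share one core and differ only in the group on the carbonyl carbon. Compound 1 `CCn1c(C(=O)Nc2ccc(OC(F)(F)F)cc2)ccc1C(CC)(CC)c1ccc(OCCC(O)(CC)CC)c(C)c1` carries a (4-(trifluoromethoxy)phenyl)amino group there. In an assay on cells for agonist activity at vitamin D3 receptor (Homo sapiens), with a stated time of 96 h (on this read-out lower numbers stand for an effect already at smaller amounts and higher numbers for an effect only at larger amounts of compound), compound 1 gives only a limit, > 10000 nM, and no number. Compound 2 `CCn1c(C(=O)N(C)CC(=O)O)ccc1C(CC)(CC)c1ccc(OCCC(O)(CC)CC)c(C)c1` carries (carboxymethyl)(methyl)amino, and in this assay compound 2 gives 89 nM. Compound 3 `CCn1c(C(=O)N(C)CCO)ccc1C(CC)(CC)c1ccc(OCCC(O)(CC)CC)c(C)c1` carries (2-hydroxyethyl)(methyl)amino, and in this assay compound 3 gives 52.7 nM, the low end of the two numbers. The gap is a 1.7-fold lower number from compound 2 to compound 3 (0.23 log units; within the scatter). Compound 4 `CCn1c(C(=O)NC(CO)CCO)ccc1C(CC)(CC)c1ccc(OCCC(O)(CC)CC)c(C)c1` changes that group: a group of 7 heavy atoms (4 carbon, 1 nitrogen, 2 oxygen; no ring) in place of a group of 5 heavy atoms (3 carbon, 1 nitrogen, 1 oxygen; no ring), on a carbonyl carbon. The steps of an at least 110-fold lower number from compound 1 to compound 2 (2.05 log units; beyond the scatter) and an at least 180-fold lower number from compound 1 to compound 3 (2.27 log units; beyond the scatter) show that replacing the aryl amide by a short chain amide lowers the number greatly, while a 1.7-fold lower number from compound 2 to compound 3 (0.23 log units; within the scatter) shows that swapping one short chain for another hardly moves it. A further chain is therefore expected to give a step of a 1.1-fold higher number from compound 3 to compound 4 (0.06 log units; within the scatter), within the scatter. Compound 4 is expected to give 60 nM, between 20 nM and 200 nM.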

Compound 4, half-maximal effective concentration: 2490 nM
Estimate against measurement, compound 4: 42-fold (1.62 log units) below; the measured number lies above the stated range.
By their numbers in this assay, from the lowest: compounds 3 and 2 (each within the scatter of the next); then compound 4. At a limit, above all of these: compound 1.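

Short chains on this carbonyl carbon are not interchangeable, since the group in compound 4 gives a 47-fold higher number from compound 3 to compound 4 (1.67 log units; beyond the scatter) and a 28-fold higher number from compound 2 to compound 4 (1.45 log units; beyond the scatter), so the exact chain matters and not only the absence of the aryl ring. Even so, this chain still compares favourably with the aryl amide, with an at least 4.0-fold lower number from compound 1 to compound 4 (0.60 log units; beyond the scatter). That step is only a bound, since compound 1 gives a limit and no number: the limit of > 10000 nM in this assay, at which 1 of the 4 values shown sits.

From the compounds shown here alone, it remains open whether the rise comes from losing the methyl on the amide nitrogen or from gaining the extra hydroxymethyl. A plain 2-hydroxyethylamino group would separate these two changes.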